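Swapping an Anilide for a Benzyl Amide: Cytotoxicity Outlook

The source may report more compounds than this note shows. Statements on the series, on what has been measured and on what is new or still open speak of the compounds shown alone.

Of the compounds shown here, three built on one shared core have been tested in an ADME assay on NCM460 cells (Homo sapiens) for cytotoxicity, read by MTT assay, with a stated time of 72 h; a lower number here means a stronger inhibitor, a higher number a weaker inhibitor. Compound 1 `Cc1ccc(N2C(=O)C/C(=C\c3cccc(C(=O)Nc4cccc(F)c4)c3)C2=O)cc1` gives only a limit of the assay, > 100000 nM, rather than a number. Compound 2 `COc1ccc(NC(=O)c2cccc(/C=C3\CC(=O)N(c4ccccc4)C3=O)c2)cc1` likewise reaches only the limit, > 100000 nM. Compound 3 `O=C(Nc1ccc(Cl)cc1)c1cccc(/C=C2\CC(=O)N(Cc3ccccc3)C2=O)c1` also sits at the limit, > 100000 nM. So compound 2 stands exactly where every measured compound stands: all three rest at the limit of > 100000 nM in this assay, at which 3 of the 3 values shown sit, and no number separates them.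

Compound 4 `O=C(NCc1ccccc1)c1cccc(/C=C2\CC(=O)N(c3ccccc3)C2=O)c1` has not yet been measured. It differs from compound 2 in one place: benzyl in place of 4-methoxyphenyl on an amide-type nitrogen. No step between measured compounds is shown, so the size of this change cannot be read from any measured pair. Because every measured value rests at the limit of > 100000 nM in this assay, at which 3 of the 3 values shown sit, the expectation for compound 4 is that it too stays at the limit. The expected step is a step that the limit leaves unreadable from compound 2 to compound 4, none beyond the scatter. Compound 4 is estimated at 150000 nM, within a range from 70000 nM to 400000 nM.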

Compound 4, half-maximal inhibitory concentration: > 100000 nM
Compound 4: only a limit was reported; the forecaster's own chance of this, stated with the estimate: 85%; the middle value does not contradict the limit.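

Compound 2 and compound 4 each give only a limit of the assay rather than a number, so no step can be read between them. The compounds shown leave open whether benzyl in place of 4-methoxyphenyl changes the result in this assay at all.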